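The source may report more compounds than this note shows. Statements on the series, on what has been measured and on what is new or still open speak of the compounds shown alone.

Measured in a functional assay on cells (Platelet, Homo sapiens) for inhibition; on this read-out lower numbers stand for stronger inhibition and higher numbers for weaker inhibition:
compound 1 `CCOC(=O)c1ccc(-c2nn(Cc3ccc(Cl)cc3)c3ccccc23)cc1`: 120 nM
compound 2 `CCOC(=O)c1ccc(-c2nn(Cc3ccc(F)cc3)c3ccccc23)cc1`: 190 nM
compound 3 `CCOC(=O)c1ccc(-c2nn(Cc3cccc(OC)c3)c3ccccc23)cc1`: 260 nM

Compound 1 gives the lowest of the three numbers, but the spread is narrow: a 1.6-fold higher number from compound 1 to compound 2 (0.20 log units; within the scatter), while a 2.2-fold higher number from compound 1 to compound 3 (0.34 log units; beyond the scatter). Compound 4 `CCOC(=O)c1ccc(-c2nn(Cc3cccnc3)c3ccccc23)cc1` is not yet measured. Its change from compound 1 is pyridin-3-yl in place of 4-chlorophenyl on a saturated chain carbon bound to an aromatic nitrogen. Both measured steps alter the group on this same saturated chain carbon bound to an aromatic nitrogen, and both moved the number up by a small amount. Because a 2.2-fold higher number from compound 1 to compound 3 (0.34 log units; beyond the scatter), replacing the whole aryl group at this place has so far cost a modest step, and a similar or slightly larger rise is expected here: a 2.7-fold higher number from compound 1 to compound 4 (0.43 log units; beyond the scatter). For compound 4 the expected value in this assay is 320 nM, with a range from 130 nM to 800 nM.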

Compound 4, half-maximal inhibitory concentration: 5550 nM
Compound 4: middle estimate off by 17-fold (1.24 log units), on the low side; measured number outside the range, above it.
By their numbers in this assay, from the lowest: compounds 1, 2 and 3 (each within the scatter of the next, the first and the last beyond it); then compound 4.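

Exchanging the carbon-only aryl group for pyridin-3-yl on the saturated chain carbon bound to an aromatic nitrogen gives large steps (a 46-fold higher number from compound 1 to compound 4 (1.67 log units; beyond the scatter)), (a 29-fold higher number from compound 2 to compound 4 (1.47 log units; beyond the scatter)) and (a 21-fold higher number from compound 3 to compound 4 (1.33 log units; beyond the scatter)) in this assay. The earlier changes among 4-chlorophenyl, 4-fluorophenyl and 3-methoxyphenyl gave no hint of a change of this size at this place. Nothing available here accounts for the rise.

Still open, as far as these compounds go, is whether pyridin-2-yl or pyridin-4-yl behaves like pyridin-3-yl. Also open, from the compounds shown here alone, is whether a chloro group on the pyridine ring would bring the number back down.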